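Swapping the Ethyl Arm for a Fluoro-Methyl Pattern

This account rests on a few compounds, and the source may have more. Where it says the series, first, only, none or still open, it means among the compounds named here.

Compound 3 `CCc1ccc(C(=O)Nc2cccc(-c3oc4cc(-c5ccc(F)cc5)ccc4c(=O)c3O)c2)cc1` is the weakest of three measured amides: in a functional assay on HeLa cells (Homo sapiens) for antiproliferative activity, read by CCK-8 assay, with a stated time of 72 h (a higher number here means a weaker inhibitor, a lower number a stronger inhibitor), compound 3 gives 21000 nM, the highest number in the set. Compound 1 `COc1ccc(C(=O)Nc2cccc(-c3oc4cc(-c5ccc(F)cc5)ccc4c(=O)c3O)c2)cc1` gives 4820 nM and compound 2 `COc1cccc(C(=O)Nc2cccc(-c3oc4cc(-c5ccc(F)cc5)ccc4c(=O)c3O)c2)c1` gives 5650 nM; the gap a 1.2-fold higher number from compound 1 to compound 2 (0.07 log units; within the scatter) is small, whereas a 4.4-fold higher number from compound 1 to compound 3 (0.64 log units; beyond the scatter) and a 3.7-fold higher number from compound 2 to compound 3 (0.57 log units; beyond the scatter) both show weaker inhibition once an ethyl group stands in for methoxy. Compound 4 `Cc1cc(C(=O)Nc2cccc(-c3oc4cc(-c5ccc(F)cc5)ccc4c(=O)c3O)c2)ccc1F` carries 4-fluoro-3-methylphenyl in place of 4-ethylphenyl on a carbonyl carbon. Within the data shown here, no measured step exchanges this exact pair of groups, so the two steps leading into compound 3 are the only guide, and they show that changing this carbonyl-bound ring moved the number by a modest amount. The estimated step of a 2.3-fold lower number from compound 3 to compound 4 (0.37 log units; beyond the scatter) is expected to point toward a lower number. Compound 4 is expected at 9000 nM, within a range from 3500 nM to 25000 nM.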

Compound 4, half-maximal inhibitory concentration: 18900 nM
Compound 4: middle estimate off by 2.1-fold (0.32 log units), on the low side; the range from low to high includes it.
By their numbers in this assay, from the lowest: compounds 1 and 2 (each within the scatter of the next); then compounds 4 and 3 (each within the scatter of the next).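

In this assay, 4-fluoro-3-methylphenyl and 4-ethylphenyl on the carbonyl carbon stand level within the scatter (a 1.1-fold lower number from compound 3 to compound 4 (0.05 log units; within the scatter)). A second non-methoxy ring also gives a higher number than either methoxy ring (a 3.3-fold higher number from compound 2 to compound 4 (0.52 log units; beyond the scatter); a 3.9-fold higher number from compound 1 to compound 4 (0.59 log units; beyond the scatter)), so across these four compounds, both methoxy amides give lower numbers than both others. No evidence here explains that gap. Still open, going by these compounds, is how this position would respond to a ring carrying an amine or a carboxylic acid.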